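This account rests on a few compounds, and the source may have more. Where it says the series, first, only, none or still open, it means among the compounds named here.

Measured compounds:
compound 1, `COc1cc(-c2nn(-c3cccc(NC(=O)Nc4cc(C(F)(F)F)cc(C(F)(F)F)c4)c3)cc2-c2ccncc2)ccc1Cl`, 3390 nM
compound 2, `COc1cc(-c2nn(-c3cccc(NC(=O)Nc4ccc(Cl)c(Cl)c4)c3)cc2-c2ccncc2)ccc1Cl`, 49500 nM

Both compounds share one core and differ only in the groups carried by the ring at the far end of the urea. In a functional assay on KM12 cells (Homo sapiens) for inhibition, read by sulforhodamine B assay, with a stated time of 48 h (on this read-out higher numbers stand for lower toxicity in this test and lower numbers for higher toxicity in this test), compound 1 gives 3390 nM, whereas compound 2 gives 49500 nM. Compound 1 thus stands at the lowest of the two numbers, and its gap to compound 2 lies beyond the scatter, so compound 1 is the more toxic of the pair in this test.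

Compound 3, `COc1cc(-c2nn(-c3cccc(NC(=O)Nc4cccc(C(F)(F)F)c4)c3)cc2-c2ccncc2)ccc1Cl`, is still to be measured. It keeps the core of compound 1 and differs in a single place: hydrogen in place of trifluoromethyl on an aromatic carbon. One trifluoromethyl group stays in place.

Going by the values given here, no measured pair shows this exact step, so the expectation rests on what the two measured compounds show. Compound 2, carrying two chlorines instead of two trifluoromethyl groups, is much less toxic than compound 1, and the change to compound 3 is partial. Compound 3 is therefore expected to become less toxic than compound 1, with an estimated 10000 nM (range 3500 nM to 30000 nM). The estimate amounts to a 2.9-fold higher number from compound 1 to compound 3 (0.47 log units; beyond the scatter), a step expected to exceed the scatter.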

Compound 3, concentration lethal to 50% of the cells: > 50000 nM
Compound 3 gave a limit, no number (the forecaster's own chance of this, stated with the estimate: 10%); middle value at least 5.0-fold (0.69 log units) from the limit.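

In this assay, compound 3 reaches a limit of the assay and not a number: the limit of > 50000 nM in this assay, at which 1 of the 3 values shown sits.

Placing hydrogen where one trifluoromethyl group stood gives an at least 14-fold higher number from compound 1 to compound 3 (1.16 log units; beyond the scatter), a large step even though the other trifluoromethyl group stays in place. The two earlier compounds differed in more than one group on that ring, so they could not tie any change to a single position, whereas this step shows that one position alone can carry a large change in this test: with the second trifluoromethyl group, compound 1 gives a readable number, and without it, compound 3 does not.

Placing 3-(trifluoromethyl)phenyl where 3,4-dichlorophenyl stood gives a number no lower from compound 2 to compound 3 (the limit leaves the size open), so the size of this step cannot be read, and these numbers do not explain why removing the trifluoromethyl group has such a large effect. On these data alone, it also remains open whether another group on this aromatic carbon, such as a nitrile or an amine, would keep the number of compound 1 or behave as hydrogen does.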